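The compounds below may be only part of what the source reports. "The series", "measured", "known", "first", "only" and "open" are said of these compounds alone.

Among the measured compounds shown here, in a functional assay on A549 cells (Homo sapiens) for inhibition, with a stated time of 48 h (on this read-out lower numbers stand for stronger inhibition and higher numbers for weaker inhibition), compound 3 (`C[S+]([O-])/C=C/c1cc(=O)c2ccccc2o1`) gives 10000 nM, the only true number among the measured compounds. Compound 1 (`COc1cc2oc(/C=C/[S+](C)[O-])cc(=O)c2cc1O`) is recorded only as a limit, > 10000 nM. Compound 2 (`COc1cc2oc(/C=C/[S+](C)[O-])cc(=O)c2cc1OC`) is likewise recorded only as a limit, > 10000 nM. Compound 4 (`COc1ccc2c(=O)cc(/C=C/[S+](C)[O-])oc2c1`) differs from compound 3 by methoxy in place of hydrogen on an aromatic carbon. For the measured compounds named here, the only measured step is a step that the two limits leave unreadable from compound 1 to compound 2, which gives no usable size. More relevant is the limit of > 10000 nM in this assay, at which 2 of the 3 values shown sit, since compound 1 and compound 2, both carrying methoxy, sit there. In this assay, the expected change is a 1.4-fold higher number from compound 3 to compound 4 (0.15 log units; within the scatter), leaning toward weaker inhibition and possibly ending at the limit. The estimate for compound 4 is 14000 nM, with an expected range from 7000 nM to 40000 nM.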

Compound 4, half-maximal inhibitory concentration: 10500 nM
Beside the measured number, compound 4's estimate is 1.3-fold (0.12 log units) above it, and the stated range covers the measured number.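

In this assay methoxy in place of hydrogen on this aromatic carbon amounts to a 1.1-fold higher number from compound 3 to compound 4 (0.02 log units; within the scatter) and so stays inside the usual scatter. Compound 4 thus carries methoxy and still gives a true number, which compound 1 and compound 2 did not show. The steps to compound 4 from those two compounds cannot be read, and their values remain limits: the limit of > 10000 nM in this assay, at which 2 of the 4 values shown sit.

The compounds shown leave open whether an amine or a carboxylic acid on this aromatic carbon would move the number beyond the scatter. On these data alone, whether a longer chain such as ethoxy would do so also stays open.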